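A few compounds are considered here, and "the series" means these few. Any claim that something is new, unique, unknown or untested is made for them only; others in the source may bear on it.

In an ADME assay on MT4 cells (Homo sapiens) for cytotoxicity, read by MTT assay (on this read-out higher numbers stand for lower toxicity in this test and lower numbers for higher toxicity in this test), three compounds of a shared core have been measured, and each returns only a limit. Compound 1 `Cc1cnc(Nc2ccc(C#N)cc2)nc1Cc1c(F)cccc1F` gives > 74300 nM, a limit of the assay rather than a number. Compound 2 `CC(c1cc(Cl)nc(Nc2ccc(C#N)cc2)n1)c1c(F)cccc1F` gives > 2690 nM, again a limit. Compound 3 `Cc1c(Cl)nc(Nc2ccc(C#N)cc2)nc1Cc1c(F)cccc1F` gives > 2690 nM, also a limit. The step that the two limits leave unreadable from compound 1 to compound 3, chloro in place of hydrogen on an aromatic carbon, is not readable, both its ends being limits. Compound 2 thus stands at the limit of > 2690 nM in this assay, at which 2 of the 3 values shown sit. Compound 1 alone sits at the limit of > 74300 nM in this assay, at which 1 of the 3 values shown sits. Compound 4 `CC(c1cc(N)nc(Nc2ccc(C#N)cc2)n1)c1c(F)cccc1F` differs from compound 2 by amino in place of chloro on an aromatic carbon. For the measured compounds named here, no measured step bears readably on this change, since the only step between measured compounds is itself unreadable, and the expected step that the limit leaves unreadable from compound 2 to compound 4 is therefore none beyond the scatter. Compound 4 is accordingly estimated at 30000 nM, within 2690 nM to 200000 nM, and is expected most likely to be reported again only as a limit.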

Compound 4, half-maximal cytotoxic concentration: 46100 nM
For compound 4 the middle estimate is 1.5-fold (0.19 log units) below the measured one; the range from low to high includes it.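

The change from compound 2 to compound 4 gives no readable step in this assay, as compound 2 stands only as a limit. The compounds shown leave open how large amino in place of chloro on an aromatic carbon is, and in which direction it goes.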